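The source may report more compounds than this note shows. Statements on the series, on what has been measured and on what is new or still open speak of the compounds shown alone.

Of the compounds shown here, three have so far been tested in a functional assay on CCRF-CEM cells (Homo sapiens), read by cell counting, with a stated time of 72 h; a higher number here means a weaker inhibitor, a lower number a stronger inhibitor. Compound 1, `Cc1ccc(/C=C/c2ccc(N(C)C)cc2)cc1`, gives only a limit in this assay, > 200 ug/mL, and not a number. Compound 2, `Fc1ccc(/N=C/c2ccccc2Cl)cc1Cl`, gives 10 ug/mL in this assay. Going by the values given here, compound 3, `Cc1ccc(/C=C/c2ccccc2F)cc1`, gives 78 ug/mL in this assay, the highest of the two numbers so far; compound 2 sits at a lower number, and the gap between the two lies beyond the usual scatter of repeated measurements. The value of compound 1 is a limit and cannot be ranked against them.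

Compound 4, `Fc1ccc(/C=C/c2ccccc2F)cc1`, has not yet been measured. It differs from compound 3 in one place: fluoro in place of methyl on an aromatic carbon. Among the compounds with values here, no pair of measured compounds shows what this exchange does to the number in this assay, so the expectation rests on the structural change alone. The step expected is a 1.1-fold lower number from compound 3 to compound 4 (0.05 log units; within the scatter), which is to say no change beyond the scatter in either direction. Compound 4 is therefore estimated at 70 ug/mL in this assay, with a range from 35 ug/mL to 140 ug/mL.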

Compound 4, half-maximal inhibitory concentration: 83 ug/mL
Compound 4: middle estimate off by 1.2-fold (0.07 log units), on the low side, and the stated range covers the measured number.
By their numbers in this assay, from the lowest: compound 2; then compounds 3 and 4 (each within the scatter of the next). At a limit, above all of these: compound 1.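

In this assay, going by these compounds alone, the exchange of methyl for fluoro on this aromatic carbon gives a 1.1-fold higher number from compound 3 to compound 4 (0.03 log units; within the scatter), the first step that can be read directly. At this place on the ring, para to a group of 9 heavy atoms, the assay therefore does not tell these two groups apart, and each is a single heavy atom with no net charge and no hydrogen-bond donors or acceptors. Compound 1 alone gives a limit and not a number, so this step rests on two true readings: the limit of > 200 ug/mL in this assay, at which 1 of the 4 values shown sits.

The compounds shown leave open whether any group on this carbon can move the number beyond the scatter, for instance an amine, a carboxylic acid or a longer chain, each quite unlike methyl and fluoro. They also show this exchange on one pair only, so whether fluoro and methyl would again match on another core, or at another place on this ring, remains an open question.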